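Carboxy gives way to hydroxymethyl: what to expect

The source may hold more compounds than are shown below. What is called first, only, known or untested is meant among the compounds shown, and "the series" means these compounds.

Measured in a functional assay on HepG2 cells (Homo sapiens) for cytotoxicity, read by WST assay, with a stated time of 24 h; a higher number here means that more compound is tolerated, a lower number that less compound is tolerated
Compound 1 `Cc1cc(-c2ccc3cc(CO)ccc3c2)ccc1O` gives > 32 ug/mL as a limit of the assay
Compound 2 `CCCCCc1cc(-c2ccc3cc(CO)ccc3c2)ccc1O` gives 3.27 ug/mL as a number
Compound 3 `CCCCCCCC=Cc1cc(-c2ccc3cc(C(=O)O)ccc3c2)ccc1O` gives 2.6 ug/mL as a number

Compound 3 (2.6 ug/mL) stands within the usual scatter of compound 2 (3.27 ug/mL). Compound 4 `CCCCCCCC=Cc1cc(-c2ccc3cc(CO)ccc3c2)ccc1O` carries hydroxymethyl in place of carboxy on an aromatic carbon. Among the measured compounds shown here, no measured step makes this exchange. The only one, an at least 9.7-fold lower number from compound 1 to compound 2 (0.99 log units; beyond the scatter) with butyl in place of hydrogen on a saturated chain carbon, lies beyond the scatter but changes the chain, not this group. Compound 2 (3.27 ug/mL) carries hydroxymethyl on a shorter chain, so the expected step, a 1.2-fold higher number from compound 3 to compound 4 (0.06 log units; within the scatter) in this assay, stays within the scatter. The estimated value for compound 4 is 3 ug/mL with an expected range (1.3 ug/mL to 7 ug/mL).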

Compound 4, concentration lethal to 50% of the cells: 5.51 ug/mL
For compound 4 the middle estimate is 1.8-fold (0.26 log units) below the measured one; the measured number falls inside the stated range.
By their numbers in this assay, from the lowest: compounds 3, 2 and 4 (each within the scatter of the next, the first and the last beyond it). At a limit, above all of these: compound 1.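

In this assay the exchange itself now has a measured size: a 2.1-fold higher number from compound 3 to compound 4 (0.33 log units; beyond the scatter) with hydroxymethyl in place of carboxy, a modest move at this aromatic carbon. Non-1-en-1-yl in place of pentyl gives a 1.7-fold higher number from compound 2 to compound 4 (0.23 log units; within the scatter) and stays within the scatter, while non-1-en-1-yl in place of methyl gives an at least 5.8-fold lower number from compound 1 to compound 4 (0.76 log units; beyond the scatter) as the larger step. That last step starts from a limit, not a number: the limit of > 32 ug/mL in this assay, at which 1 of the 4 values shown sits.

Going by these compounds, whether an amine or an amide on this aromatic carbon would sit closer to carboxy or to hydroxymethyl stays open. So does what a longer chain would do.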